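A few compounds are considered here, and "the series" means these few. Any claim that something is new, unique, unknown or untested is made for them only; others in the source may bear on it.

Series notes. In an ADME assay on BJ cells (Homo sapiens) for antiproliferative activity, with a stated time of 72 h (a lower number here means that less compound is needed, a higher number that more compound is needed for the effect), compound 1 `COc1ccc(-c2cc(=O)c3c(OC)cc(OC)cc3[nH]2)cc1` gives > 62000 nM, which is a limit of the assay, not a number. Compound 2 `COc1ccc(-c2[nH]c3cc(OC)cc(OC)c3c(=O)c2I)cc1` gives > 86200 nM in this assay, again a limit. Compound 3 `COC(=O)c1cc(=O)c2cc(N)ccc2[nH]1` gives > 67200 nM in this assay, also a limit. The only one-place step among these, a step that the two limits leave unreadable from compound 1 to compound 2, runs between two limits and is therefore of unreadable size, as the limit of > 62000 nM in this assay, at which 1 of the 3 values shown sits, and the limit of > 86200 nM in this assay, at which 1 of the 3 values shown sits, show; the limit of > 67200 nM in this assay, at which 1 of the 3 values shown sits, adds a third limit. Compound 1 thus stands at a limit, with no numbered value anywhere in the set.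

Compound 4 `COc1ccc(-c2cc(=O)c3c(OC)cc(OC)cc3n2S(=O)(=O)c2ccc(C#N)cc2)cc1` differs from compound 1 by (4-cyanophenyl)sulfonyl in place of hydrogen on an aromatic nitrogen. For the measured compounds named here, no measured step bears directly on this change. With every shown value at a limit, the expected step that the limit leaves unreadable from compound 1 to compound 4 is none beyond scatter, and compound 4 is estimated at 80000 nM with range 20000 nM to 250000 nM in this assay.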

Compound 4, half-maximal effective concentration: > 17200 nM
Compound 4 gave a limit, no number; the forecaster's own chance of this, stated with the estimate: 75%; the middle value lies beyond the limit too.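

In this assay, for the compounds shown here, compound 1 and compound 4 both stand at limits, so no step between them can be read. The compounds shown leave open whether any change on the core of compound 1 gives a numbered value in this assay.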